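Oxazole in place of isobutyl on the amide nitrogen

The source may hold more compounds than are shown below. What is called first, only, known or untested is meant among the compounds shown, and "the series" means these compounds.

Measured so far in an assay on HEK293 cells for agonist activity at transient receptor potential cation channel subfamily M member 8 (Homo sapiens), read by fluorescence and calcium flux, with a stated time of 15 min; a higher number here means that more compound is needed for the effect, a lower number that less compound is needed:
compound 1 `Cc1ccc(OCC(=O)N(Cc2cccs2)c2ccn(C)n2)cc1` gives 855 nM
compound 2 `Cc1ccc(OCC(=O)N(Cc2cccs2)CC(C)C)cc1` gives 900 nM

Compound 2 stands at the highest of the two numbers in this assay, but its nearest neighbour is compound 1, and the step of a 1.1-fold higher number from compound 1 to compound 2 (0.02 log units; within the scatter) lies within the scatter, so the two compounds cannot be told apart on these data. Compound 3 `Cc1ccc(OCC(=O)N(Cc2cccs2)c2ncco2)cc1` has not yet been measured. It differs from compound 2 in one place: 1,3-oxazol-2-yl in place of isobutyl on an amide-type nitrogen. Among the compounds with values here, the only measured step that bears on this change is a 1.1-fold higher number from compound 1 to compound 2 (0.02 log units; within the scatter), which exchanged an aromatic ring on the same amide-type nitrogen for isobutyl and gave no shift beyond the scatter. The change to compound 3 goes the other way, putting an aromatic ring back in place of isobutyl, so no step beyond the scatter is expected in this assay. The estimated step of a 1.1-fold lower number from compound 2 to compound 3 (0.02 log units; within the scatter) is therefore small. Compound 3 is expected to give about 850 nM, with a likely range from 400 nM to 1800 nM.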

Compound 3, half-maximal effective concentration: 0.3 nM
The estimate for compound 3 lay 2800-fold (3.45 log units) above the measured number, and the stated range ends above it.
By their numbers in this assay, from the lowest: compound 3; then compounds 1 and 2 (each within the scatter of the next).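

In this assay, the group on the amide-type nitrogen proves able to move the number enormously, which compound 1 and compound 2 gave no sign of: 1,3-oxazol-2-yl in place of isobutyl brings a 3000-fold lower number from compound 2 to compound 3 (3.48 log units; beyond the scatter). The change is not simply one of a ring for an open chain, since 1,3-oxazol-2-yl in place of 1-methyl-1H-pyrazol-3-yl, itself a five-membered aromatic ring, brings a 2900-fold lower number from compound 1 to compound 3 (3.45 log units; beyond the scatter), so among the three groups shown, the large drop goes with the oxazole alone and compound 1 goes against any reading that credits an aromatic ring as such. Nothing measured here says what lies behind this drop.

Going by these compounds, it remains open whether the low number survives with a closely related ring at this place, such as 1,3-thiazol-2-yl, with sulfur in place of the ring oxygen, or 1,3-oxazol-4-yl, or whether a plain phenyl ring would do. The compounds shown also leave open whether 1,3-oxazol-2-yl would have a step of this size on a different core, since all three share one core.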